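The source may hold more compounds than are shown below. What is called first, only, known or untested is meant among the compounds shown, and "the series" means these compounds.

Measured so far:
compound 1 `CCCCCCc1cn(C(c2ccccc2)c2ccccc2)nn1` — 14800 nM
compound 2 `Clc1ccc(OCc2cn(C(c3ccccc3)c3ccccc3)nn2)cc1` — 13400 nM

In an assay on isolated protein for inhibition of Aromatase (Homo sapiens), read by fluorescence and colorimetric assay, with a stated time of 30 min (a higher number here means a weaker inhibitor, a lower number a stronger inhibitor), compound 2 gives 13400 nM, and compound 1 gives 14800 nM. Within the data shown here, the one step measured, a 1.1-fold lower number from compound 1 to compound 2 (0.04 log units; within the scatter), is within the scatter, so the two values of compound 1 and compound 2 are not separable; compound 2 simply holds the smaller of two numbers that sit together.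

Compound 3 `Clc1ccc(OCc2cn(Cc3ccccc3)nn2)cc1` is the next member. It differs from compound 2 by hydrogen in place of phenyl on a saturated chain carbon bound to an aromatic carbon and an aromatic nitrogen. Among the measured compounds shown here, no measured step touches this place: the step from compound 1 to compound 2 changed a substituent on the other side of the shared core and bears on compound 3 only indirectly, as a sign that one exchange elsewhere left the number in place. There is thus no shown step from which to read the direction here, and the expectation rests on the structural change alone.

Compound 3 is expected to stay in the same weak range, with a step of a 1.5-fold higher number from compound 2 to compound 3 (0.17 log units; within the scatter) estimated. The estimate for compound 3 in this assay is 20000 nM, with a range from 6000 nM to 60000 nM.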

Compound 3, half-maximal inhibitory concentration: 5040 nM
Estimate against measurement, compound 3: 4.0-fold (0.60 log units) above; measured number below the stated range.
By their numbers in this assay, from the lowest: compound 3; then compounds 2 and 1 (each within the scatter of the next).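

In this assay, this position responds where the earlier exchange did not: the change of phenyl to hydrogen on the saturated chain carbon bound to an aromatic carbon and an aromatic nitrogen gives a 2.7-fold lower number from compound 2 to compound 3 (0.42 log units; beyond the scatter), whereas the exchange on the other side of the shared core gave a 1.1-fold lower number from compound 1 to compound 2 (0.04 log units; within the scatter). Inhibition at the level of compound 3 therefore does not require the phenyl lost from compound 2, and this is the first place in the series where a single change moves the number beyond the scatter, though only modestly. Nothing available explains why removing this phenyl lowers the number.

From the compounds shown here alone, it remains open whether a small group at this carbon, such as methyl, would give a number closer to that of compound 2 or compound 3, and whether the remaining phenyl would tolerate a substituent such as an amine or a carboxylic acid. Also open, going by these compounds, is whether the same change of phenyl to hydrogen would give a similar step with the chain of compound 1 in place of the 4-chlorophenoxy group.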